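Chloro to cyclopropyl on the shared core

The compounds below may be only part of what the source reports. "The series", "measured", "known", "first", "only" and "open" are said of these compounds alone.

compound 1 `O=C(NCc1ccccc1)Nc1[nH]nc(-c2ccccn2)c1Cl` | > 64000 nM
compound 2 `O=C(Nc1cc(-c2ccccn2)n[nH]1)N1CCC(Oc2ccccc2)CC1` | > 40000 nM

In an ADME assay on cells (Peritoneal macrophage cell, Mus musculus) for cytotoxicity, read by fluorescence and resazurin assay, with a stated time of 3 days (a lower number here means that less compound is tolerated, a higher number that more compound is tolerated), compound 1 gives > 64000 nM as a limit and not a number. Compound 2 gives > 40000 nM in this assay as a limit too. Compound 1 thus has no exact value, and no measured number exists in the series to place it against.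

Compound 3 `O=C(NCc1ccccc1)Nc1[nH]nc(-c2ccccn2)c1C1CC1` keeps the rest of compound 1 and carries cyclopropyl in place of chloro on an aromatic carbon of a five-membered aromatic ring with 2 nitrogen. Among the compounds with values here, no measured pair isolates this position.

In this assay no step beyond the usual scatter is expected, and a limit is again the likeliest report for compound 3. The estimated change is an at least 1.1-fold lower number from compound 1 to compound 3 (0.06 log units; that floor lies within the scatter) and is expected to stay small. This expectation rests first on compound 1 at > 64000 nM as a limit. It rests also on compound 2 at > 40000 nM as a limit.

Compound 3 is expected at 55000 nM as an estimate, with an estimated range of 25000 nM to 100000 nM in this assay.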

Compound 3, half-maximal cytotoxic concentration: > 45000 nM
Compound 3: a limit, no number (the forecaster's own chance of this, stated with the estimate: 75%); the middle value lies beyond the limit too.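

In this assay compound 3 gives > 45000 nM, a limit and not a number. Compound 1 gives > 64000 nM, also a limit. No step can be read between compound 1 and compound 3. The compounds shown leave open where the half-maximal cytotoxic concentration of either compound lies, and whether cyclopropyl in place of chloro shifts it at all.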